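The compounds below may be only part of what the source reports. "The series", "measured", "known", "first", "only" and "open" are said of these compounds alone.

Compound 1 `FC(F)(F)c1cccc(-c2nc3cnc(Nc4ccncn4)cc3[nH]2)c1` stands highest of the three numbers in a physicochemical assay for solubility, using the shake flask method, measured as kinetic solubility, with a stated time of 20 h, at pH 2 (on this read-out higher numbers stand for higher solubility and lower numbers for lower solubility), giving 200000 nM. Compound 2 `Fc1ccc(-c2nc3cnc(Nc4ccccn4)cc3[nH]2)cc1F` gives 125000 nM, within the scatter of compound 1, while compound 3 `Fc1ccc(Nc2cc3[nH]c(-c4ccc(F)c(F)c4)nc3cn2)nc1` gives 42000 nM, beyond it. Compound 4 `O=C(O)c1ccnc(Nc2cc3[nH]c(-c4cccc(C(F)(F)F)c4)nc3cn2)c1` differs from compound 1 by 4-carboxypyridin-2-yl in place of pyrimidin-4-yl on a nitrogen on an aromatic ring. Within the data shown here, the only measured step, a 3.0-fold lower number from compound 2 to compound 3 (0.47 log units; beyond the scatter), concerns a different change and bears at most loosely on this one. Among the measured compounds shown here, no measured pair shows an exchange of this kind on the ring nitrogen, so the expectation rests on the starting point alone: compound 4 is expected to show a 2.2-fold lower number from compound 1 to compound 4 (0.35 log units; beyond the scatter) in this assay, a step that may stay within the scatter or run modestly lower. The solubility of compound 4 is estimated at 90000 nM, ranging from 20000 nM to 300000 nM.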

Compound 4, solubility: < 5000 nM
Compound 4 was reported as a limit; the forecaster's own chance of this, stated with the estimate: 5%; middle value at least 18-fold (1.25 log units) away from the limit.
By their numbers in this assay, from the lowest: compound 3; then compounds 2 and 1 (each within the scatter of the next). At a limit, below all of these: compound 4.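

In this assay, among these compounds, the group on this nitrogen proves able to carry a far larger step than the earlier compounds showed: 4-carboxypyridin-2-yl in place of pyrimidin-4-yl brings an at least 40-fold lower number from compound 1 to compound 4 (1.60 log units; beyond the scatter), against a 3.0-fold lower number from compound 2 to compound 3 (0.47 log units; beyond the scatter) for the only earlier step. The result for compound 4 is a limit, not a number: the limit of < 5000 nM in this assay, at which 1 of the 4 values shown sits.

From the compounds shown here alone, whether the step belongs to the carboxylic acid or to the ring that carries it stays open. So does whether an amine or an amide in the place of the carboxylic acid would stay closer to compound 1 or to compound 4.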